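A few compounds are considered here, and "the series" means these few. Any claim that something is new, unique, unknown or untested is made for them only; others in the source may bear on it.

Measured compounds:
compound 1, `Cc1ccc(CN2CCC(NC(=O)N(CC(=O)C(C)(C)O)Cc3ccc(-c4cccc(C#N)c4)cc3)CC2)cc1`, gives 84.5% in an in vitro functional assay on HEK293 cells for antagonist activity at melanin-concentrating hormone receptor 1 (Homo sapiens); on this read-out lower numbers stand for smaller maximal responses and higher numbers for larger maximal responses;
compound 2, `Cc1ccc(CN2CCC(CCN(Cc3ccc(-c4ccc(F)cc4)cc3)C(=O)NC(C)C)CC2)cc1`, gives 113%;
compound 3, `COc1ccc(-c2ccc(CN(CCC3CCN(Cc4ccc(C)cc4)CC3)C(=O)NC(C)C)cc2)cc1`, gives 91.5%.

Among these three numbers compound 3 stands second highest. Its nearest neighbour is compound 1, whose value lies lower by an amount within the usual scatter, so no order between the two can be claimed. Going by the values given here, its furthest neighbour is compound 2, and the one single-point step among the measured compounds, a number 21.5 percentage points lower from compound 2 to compound 3 (beyond the scatter), lies beyond the scatter and is modest in size.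

Compound 4, `Cc1ccc(CN2CCC(CCN(Cc3ccc(-c4cccc(C#N)c4)cc3)C(=O)NC(C)C)CC2)cc1`, differs from compound 3 in one place: 3-cyanophenyl in place of 4-methoxyphenyl on an aromatic carbon. Among the compounds with values here, the only measured step that bears on this change is a number 21.5 percentage points lower from compound 2 to compound 3 (beyond the scatter), which swapped one group on the same aromatic carbon and moved the largest response by a modest amount. Within the data shown here, compound 1 also carries the 3-cyanophenyl, but on a different core, and no single-point step connects it to compound 3; their two values simply sit within the scatter of each other. For compound 4 a shift no larger than modest is therefore expected, most likely a small one, a number 3.5 percentage points lower from compound 3 to compound 4 (within the scatter). Compound 4 is accordingly estimated at 88%, with a range from 70% to 108%.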

Compound 4, largest response reached (reported as Imax), in percent of the reference or control that the assay uses: 97%
Compound 4: the middle estimate sits 9 percentage points below what was measured; measured number inside the range.
By their numbers in this assay, from the lowest: compounds 1, 3 and 4 (each within the scatter of the next, the first and the last beyond it); then compound 2.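

In this assay the exchange of 4-methoxyphenyl for 3-cyanophenyl on this aromatic carbon, para to a large group, gives a number 5.5 percentage points higher from compound 3 to compound 4 (within the scatter) and so draws no distinction between the two groups. The same carbon carrying 3-cyanophenyl in place of 4-fluorophenyl gives a number 16 percentage points lower from compound 2 to compound 4 (beyond the scatter) and so shows that a second, different group also ends beyond the scatter of compound 2, which until now rested on the 4-methoxyphenyl alone. Among the three groups seen on this carbon, only the 4-fluorophenyl of compound 2 at 113% stands apart from the other two, and the replacements with a methoxy and with a nitrile, which share no other feature counted here beyond the single hydrogen-bond acceptor, cannot be told apart in this read-out.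

On these data alone, how an unsubstituted phenyl group or a carboxylic acid on that ring would compare remains open, and three groups are too few to say whether the position of compound 2 reflects a general rule. No measurement at hand accounts for why compound 2 stands apart from compound 3 and compound 4.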